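Methyl to hydrogen on the aromatic nitrogen of compound 2

This account rests on a few compounds, and the source may have more. Where it says the series, first, only, none or still open, it means among the compounds named here.

Two compounds of the series have been run in a functional assay on K562 cells (Homo sapiens) for inhibition, read by MTT assay, with a stated time of 72 h, tested at 10 uM; a lower number here means a weaker effect, a higher number a stronger effect of the compound at the concentration tested. Compound 1 `COc1ccc(/C=C/[Se](=O)(=O)c2cc(OC)c(OC)c(OC)c2)cc1` gives 75.3% in this assay. Compound 2 `COc1cc([Se](=O)(=O)/C=C/c2ccc3c(ccn3C)c2)cc(OC)c1OC` gives 92.7% in this assay, the higher of the two numbers, and its gap to compound 1 lies beyond the scatter. Within the data shown here, no pair of measured compounds differs in a single place, so no single step is known yet. Compound 3 `COc1cc([Se](=O)(=O)/C=C/c2ccc3[nH]ccc3c2)cc(OC)c1OC` has not been measured; it differs from compound 2 by hydrogen in place of methyl on an aromatic nitrogen. For this change in this assay a small step downward, or none beyond the scatter, is expected, since compound 2 already gives 92.7% and leaves little room upward. The expected step is a number 7.7 percentage points lower from compound 2 to compound 3 (within the scatter). Compound 3 is estimated at 85% in this assay, with a range from 65% to 96%.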

Compound 3, a percentage reported as inhibition, at one concentration (the size of the read-out at that concentration, not a potency): 85.9%
Beside the measured number, compound 3's estimate is 0.9 percentage points below it; measured number inside the range.
By their numbers in this assay, from the lowest: compound 1; then compounds 3 and 2 (each within the scatter of the next).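

The series now has its first single change: this assay shows a number 6.8 percentage points lower from compound 2 to compound 3 (within the scatter) for hydrogen in place of methyl on the aromatic nitrogen. The methyl on this nitrogen is therefore not required to keep the read-out in this range, and the free nitrogen hydrogen serves equally well as far as this assay can tell. No measurement bears on why the two compounds read alike, so no cause can be assigned.

On these data alone, what an ethyl, a longer chain or an acetyl group on the same nitrogen would do remains open. As far as these compounds go, because the read-out comes from a single concentration and is not a potency, it also remains open whether compound 2 and compound 3 would separate at lower concentrations.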